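Bromo to hydroxy on the pendant ring at two positions

The source may hold more compounds than are shown below. What is called first, only, known or untested is meant among the compounds shown, and "the series" means these compounds.

Measured so far in a functional assay on RAW264.7 cells (Mus musculus) for inhibition; on this read-out lower numbers stand for stronger inhibition and higher numbers for weaker inhibition:
compound 1 `O=C1/C(=C/c2ccccc2Br)CCc2cc(O)ccc21` gives 1070 nM
compound 2 `O=C1/C(=C/c2cccc(Br)c2)CCc2cc(O)ccc21` gives 1140 nM
compound 3 `O=C1/C(=C/c2ccccc2O)CCc2cc(O)ccc21` gives 550 nM

Compounds 1 and 2 share the same atoms joined differently; the difference between the two cores is not broken down here. Their values in this assay lie within the scatter of each other. For the measured compounds named here, the one change measured so far is hydroxy in place of bromo on an aromatic carbon, which gave a 1.9-fold lower number from compound 1 to compound 3 (0.29 log units; within the scatter).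

Compound 4 `O=C1/C(=C/c2cccc(O)c2)CCc2cc(O)ccc21` has not yet been measured. It stands to compound 2 as compound 3 stands to compound 1: hydroxy in place of bromo on an aromatic carbon. The place differs, ortho to a large group in the first case and meta to a large group in the second, so this is the same kind of change, not the same change.

The step from compound 2 to compound 4 is expected to be a 1.8-fold lower number from compound 2 to compound 4 (0.24 log units; within the scatter), resting on the earlier step of a 1.9-fold lower number from compound 1 to compound 3 (0.29 log units; within the scatter). For compound 4 the value in this assay is expected to be near 650 nM, between 320 nM and 1300 nM.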

Compound 4, half-maximal inhibitory concentration: 3510 nM
Beside the measured number, compound 4's estimate is 5.4-fold (0.73 log units) below it; measured number above the stated range.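

In this assay, hydroxy in place of bromo on an aromatic carbon, meta to a large group, gives a 3.1-fold higher number from compound 2 to compound 4 (0.49 log units; beyond the scatter). The change therefore does not carry between the two cores as a constant shift: the same change on two cores in this assay, a 1.9-fold lower number (0.29 log units; within the scatter) from compound 1 to compound 3 and a 3.1-fold higher number (0.49 log units; beyond the scatter) from compound 2 to compound 4, 6.0-fold (0.78 log units) apart, beyond the scatter of two such steps. This rests on one pair for each core, and it shows neither why the two steps part nor whether the place of the group alone decides the outcome.

Still open, going by these compounds, is whether the split is particular to hydroxy or also appears with other groups on the pendant ring. A methoxy, an amine or a carboxylic acid at these same places would test this.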